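Demethylation of a Compound with a Low Fucosidase Inhibition Number: An Expectation

The compounds below may be only part of what the source reports. "The series", "measured", "known", "first", "only" and "open" are said of these compounds alone.

Compound 1, `OC[C@]1(c2ccc(F)cc2)NC[C@H](O)[C@H]1O`: 0% in an assay on isolated protein for inhibition of tissue alpha-L-fucosidase (Bos taurus), tested at 1000 uM; a lower number here means less inhibition, a higher number more inhibition at the concentration tested (going by the name of the read-out)
Compound 2, `COc1ccc([C@]2(CO)NC[C@@H](O)[C@@H]2O)cc1`: 2.7% in this assay
Compound 3, `CCCCCCCCC[C@]1(CO)NC[C@@H](O)[C@@H]1O`: 0% in this assay

None of the three measured compounds shows appreciable inhibition in this assay. Among the compounds with values here, compound 2 gives 2.7%, a number that no other compound here exceeds, yet one that compound 1 with 0% and compound 3 with 0% both match within the usual scatter. No two of these compounds differ in only one place, so no single step can be read from them; the three numbers simply agree in sitting at the floor of the read-out.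

Compound 4, `OC[C@@]1(c2ccc(O)cc2)NC[C@@H](O)[C@@H]1O`, is the next to be measured in this assay. It differs from compound 2 by hydrogen in place of methyl on an oxygen on an aromatic ring. With all three measured values at the floor, the step from compound 2 is expected to be none beyond the scatter, namely a number 0.3 percentage points higher from compound 2 to compound 4 (within the scatter). Compound 4 is therefore estimated to give 3%, within a range from 0% to 12%.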

Compound 4, a percentage reported as inhibition, at one concentration (the size of the read-out at that concentration, not a potency): 0%
Compound 4: the middle estimate sits 3 percentage points above what was measured; the measured number falls inside the stated range.
By their numbers in this assay, from the lowest: compounds 1, 3, 4 and 2 (each within the scatter of the next).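

Within the data shown here, replacing methoxy with hydroxy gives the first step in this set that can be read at a single place: a number 2.7 percentage points lower from compound 2 to compound 4 (within the scatter) in this assay. On an oxygen on an aromatic ring, then, hydrogen in place of methyl leaves the number at the floor of the read-out, and a step that starts and ends at that floor cannot show whether the same change would matter in a compound with clear inhibition. No independent measurement offers an explanation for this result.

On these data alone, whether a longer chain on that oxygen, such as ethyl or benzyl, would give a number beyond the scatter remains open. So does the outcome of putting an amine or a carboxylic acid on the aromatic ring in place of the hydroxy.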